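Fluorophenyl for phenethyl on a sulfur: an expected step

The source may report more compounds than this note shows. Statements on the series, on what has been measured and on what is new or still open speak of the compounds shown alone.

Of the compounds shown here, three have been measured in a functional assay on HCT-116 cells (Homo sapiens) for inhibition, read by CCK-8 assay, with a stated time of 72 h, tested at 2 uM; on this read-out higher numbers stand for more inhibition of growth at the one concentration tested and lower numbers for less inhibition of growth. Compound 1 `Nc1ccccc1NC(=O)/C=C/c1ccc(CSc2ccc(F)cc2)cc1` and compound 2 `Nc1ccccc1NC(=O)/C=C/c1ccc(CSCCc2ccccc2)cc1` share one core and differ only on the sulfur. In this assay compound 1 gives 14.1%, and in this assay compound 2 gives 18%. The change from compound 2 to compound 1 is 4-fluorophenyl in place of phenethyl on a sulfur, and it made a step of a number 3.9 percentage points lower from compound 2 to compound 1 (within the scatter).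

Compound 3 `Nc1ccccc1NC(=O)c1ccc(CSCCc2ccccc2)cc1` carries the phenethyl on the sulfur as compound 2 does, but on a different core; the difference between the two cores is not broken down here. In this assay compound 3 gives 30.5%, which stands beyond the scatter above both compound 2 and compound 1.

Compound 4 `Nc1ccccc1NC(=O)c1ccc(CSc2ccc(F)cc2)cc1` is not yet measured. From compound 3 to compound 4 the change is 4-fluorophenyl in place of phenethyl on a sulfur, the same change that was made from compound 2 to compound 1, and it occurs twice among these compounds. Because the measured step of a number 3.9 percentage points lower from compound 2 to compound 1 (within the scatter) lies within the scatter, the step from compound 3 to compound 4 is expected to be small as well, estimated as a number 3.5 percentage points lower from compound 3 to compound 4 (within the scatter). On that basis compound 4 is expected to give about 27% in this assay, with a range from 15% to 40% expected to hold most repeated measurements.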

Compound 4, percent growth inhibition at one concentration: 13.5%
Estimate against measurement, compound 4: 13.5 percentage points above; measured number below the stated range.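

In this assay, 4-fluorophenyl in place of phenethyl on a sulfur now gives a second step, a number 17 percentage points lower from compound 3 to compound 4 (beyond the scatter), on the core that compound 3 and compound 4 share. Taken on its own this step is larger than the scatter, but set beside the earlier step on the other core, the two cannot be told apart: the same change on two cores in this assay, a number 3.9 percentage points lower (within the scatter) from compound 2 to compound 1 and a number 17 percentage points lower (beyond the scatter) from compound 3 to compound 4, 13.1 percentage points apart, within the scatter of two such steps The result therefore shows no demonstrated dependence of this change on the core, yet it does not show that the step carries over unchanged, since two pairs of compounds, read at a single concentration, leave room for a real difference of a size that the scatter of two such steps would hide.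

What the compounds shown leave open is how other groups on the sulfur would fare on either core, such as an unsubstituted phenyl, a 4-chlorophenyl, a longer chain ending in a phenyl or a chain bearing an amine. As far as these compounds go, it also remains open whether the same pattern of steps would hold at other concentrations or with a carboxylic acid on the ring that now carries the fluorine.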